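The source may report more compounds than this note shows. Statements on the series, on what has been measured and on what is new or still open speak of the compounds shown alone.

The series shares one core, carried in compound 1 `CC(C)(NC(=O)OCc1ccccc1)c1nc(O)c(O)c(NC(=O)NCc2ccc(F)cc2)n1`, compound 2 `CC(C)(NC(=O)OCc1ccccc1)c1nc(O)c(O)c(C(=O)NN)n1`, compound 3 `COCCNC(=O)Nc1nc(C(C)(C)NC(=O)OCc2ccccc2)nc(O)c1O` and the not yet measured compound 4 `CC(C)(NC(=O)OCc1ccccc1)c1nc(O)c(O)c(C(=O)NCc2ccccc2Cl)n1`. In an ADME assay on C8166 cells (Homo sapiens) for cytotoxicity, read by MTT assay, with a stated time of 3 days (a lower number here means that less compound is tolerated, a higher number that more compound is tolerated), compound 1 gives 81100 nM. Compound 2 reaches only the limit of the assay, > 500000 nM, and no number. Compound 3 likewise stops at the limit, > 500000 nM. So compound 2 sits at the limit of > 500000 nM in this assay, at which 2 of the 3 values shown sit, the upper edge of what this assay can report, with only compound 1 giving a number. The change from compound 2 to compound 4 is 2-chlorobenzyl in place of amino on an amide-type nitrogen. Among the compounds with values here, two measured steps touch it. The step of an at least 6.1-fold higher number from compound 1 to compound 3 (0.78 log units; beyond the scatter) shows that putting methoxymethyl in place of 4-fluorophenyl on a saturated chain carbon bound to an amide-type nitrogen raised the tolerated concentration; compound 4 makes the opposite kind of move, bringing in one six-membered aromatic ring of carbon only. The step that the two limits leave unreadable from compound 2 to compound 3 has no readable size. On this basis a fall in this assay is expected for compound 4, of about an at least 5.0-fold lower number from compound 2 to compound 4 (0.69 log units; beyond the scatter). Compound 4 is therefore estimated at 100000 nM, within a range from 30000 nM to 500000 nM.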

Compound 4, half-maximal cytotoxic concentration: 53900 nM
Compound 4: middle estimate off by 1.9-fold (0.27 log units), on the high side, within the range that was stated.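

In this assay, within the data shown here, the amide-type nitrogen whose other neighbour is the carbonyl carbon now gives a readable step, which the earlier compounds did not offer: 2-chlorobenzyl in place of amino gives an at least 9.2-fold lower number from compound 2 to compound 4 (0.96 log units; beyond the scatter). Exchanging the whole group on the aromatic carbon, (2-chlorobenzyl)carbamoyl in place of ((2-methoxyethyl)carbamoyl)amino, gives an at least 9.2-fold lower number from compound 3 to compound 4 (0.96 log units; beyond the scatter), so among the four compounds the two with a six-membered aromatic ring of carbon only in this group, compound 1 and compound 4, give numbers, while compound 2 and compound 3, without one, do not, and no compound shown goes against this. Both new steps start from a limit and not from a number, so they fix only a smallest size for the fall: the limit of > 500000 nM in this assay, at which 2 of the 4 values shown sit.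

The compounds shown leave open whether the ring alone accounts for the fall or the chlorine takes part in it, a question that plain benzyl or 4-chlorobenzyl on this nitrogen would address. They also leave open how a 2-aminoethyl group or a longer chain without a ring would behave at this nitrogen.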